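The compounds below may be only part of what the source reports. "The series", "measured", "known", "first", "only" and "open" are said of these compounds alone.

Measured so far:
compound 1, `Cn1ncc(Cl)c1-c1cc(C(=O)N[C@@H]2CN[C@H](CC(=O)O)C[C@H]2c2ccc(Cl)c(Cl)c2)oc1Cl` — 4020 nM
compound 2, `Cn1ncc(Cl)c1-c1cc(C(=O)N[C@H]2CNCC[C@@H]2c2ccc(C(F)(F)F)cc2)oc1Cl` — 1050 nM

In a functional assay on HCT-116 cells (Homo sapiens) for antiproliferative activity, read by sulforhodamine B assay, with a stated time of 72 h (a higher number here means a weaker inhibitor, a lower number a stronger inhibitor), compound 1 gives 4020 nM, the higher of the two numbers; compound 2 gives 1050 nM, and the gap between them lies beyond the scatter, so compound 1 is the weaker inhibitor of this pair. The two compounds differ in several places at once, so nothing can be assigned to any single change between them.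

Compound 3, `COCC[C@@H]1C[C@@H](c2ccc(Cl)c(Cl)c2)[C@H](NC(=O)c2cc(-c3c(Cl)cnn3C)c(Cl)o2)CN1`, has not been measured in this assay. It differs from compound 1 in one place: methoxymethyl in place of carboxy on a saturated chain carbon bound to a saturated ring carbon. Among the measured compounds shown here, no measured pair in the set shows the effect of this change, so the expectation rests on the position of compound 1 and the result for compound 2 alone. The expected step is downward, toward a stronger inhibitor, by an amount somewhat beyond the scatter, but with wide uncertainty. For compound 3 the expected value is 1300 nM, with a range from 400 nM to 4000 nM, which corresponds to an expected step of a 3.1-fold lower number from compound 1 to compound 3 (0.49 log units; beyond the scatter).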

Compound 3, half-maximal inhibitory concentration: 470 nM
For compound 3 the middle estimate is 2.8-fold (0.44 log units) above the measured one; the measured number falls inside the stated range.
By their numbers in this assay, from the lowest: compound 3; then compound 2; then compound 1.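

Notes on the chain position, read in this assay: methoxymethyl in place of carboxy on a saturated chain carbon bound to a saturated ring carbon gives an 8.6-fold lower number from compound 1 to compound 3 (0.93 log units; beyond the scatter) and moves the series toward a stronger inhibitor. This is the first change in the series that can be read in one place, so the position is now shown to matter on its own, which the comparison of compound 1 with compound 2 could not show. The step does not separate the loss of carboxy from the gain of methoxymethyl, and no supporting measurement bears on why the number moves.

A single pair leaves open how the result depends on the group at this place: an amine, a hydroxyl, a primary carboxamide or a longer ether chain would show whether methoxymethyl is special or whether most replacements of carboxy behave alike. On these data alone, it also remains open whether the same change gives a step of similar size when the aryl group carries trifluoromethyl, as in compound 2, rather than the two chlorines of compound 1.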